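This account rests on a few compounds, and the source may have more. Where it says the series, first, only, none or still open, it means among the compounds named here.

Series notes, shared core with a varied aryl on the double-bonded chain.

Compound 1 `O=C(/C=C/c1cccc(Cl)c1)Nc1nnc(-c2ccccc2)[nH]1` gives 1470000 nM in an ADME assay on Vero cells (Chlorocebus sabaeus) for cytotoxicity, read by MTT assay, with a stated time of 72 h; a lower number here means that less compound is tolerated, a higher number that more compound is tolerated. Compound 2 `O=C(/C=C/c1ccc(Cl)cc1)Nc1nnc(-c2ccccc2)[nH]1` gives 1620000 nM in this assay, and compound 3 `O=C(/C=C/c1ccc([N+](=O)[O-])s1)Nc1nnc(-c2ccccc2)[nH]1` gives 1670000 nM. Compound 1 therefore stands within the scatter of both other compounds: a 1.1-fold higher number from compound 1 to compound 2 (0.04 log units; within the scatter) and a 1.1-fold higher number from compound 1 to compound 3 (0.06 log units; within the scatter), and likewise a 1.0-fold higher number from compound 2 to compound 3 (0.01 log units; within the scatter). Across these three, swapping the aryl on the chain leaves the read-out unmoved.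

Compound 4 `O=C(/C=C/c1ccccc1)Nc1nnc(-c2ccccc2)[nH]1` is the unmeasured member; the change from compound 1 is hydrogen in place of chloro on an aromatic carbon, that is, 3-chlorophenyl to phenyl. Among the measured compounds shown here, no measured step removes a substituent outright, so the bearing steps are only the aryl swaps, all within the scatter. The expectation for this assay is accordingly no step beyond the scatter, a 1.1-fold higher number from compound 1 to compound 4 (0.04 log units; within the scatter). Compound 4 is estimated at 1600000 nM, with a range from 900000 nM to 2900000 nM.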

Compound 4, half-maximal cytotoxic concentration: 1570000 nM
Estimate against measurement, compound 4: 1.0-fold (0.01 log units) above, and the stated range covers the measured number.
By their numbers in this assay, from the lowest: compounds 1, 4, 2 and 3 (each within the scatter of the next).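

Taking the chloro off altogether gives a step within the scatter in this assay, whether it leaves the 3-chlorophenyl (a 1.1-fold higher number from compound 1 to compound 4 (0.03 log units; within the scatter)) or the 4-chlorophenyl (a 1.0-fold lower number from compound 2 to compound 4 (0.01 log units; within the scatter)), so at this position the series now includes a ring with no substituent as well as swapped aryls. The plain phenyl also stands within the scatter of the 5-nitrothiophen-2-yl (a 1.1-fold lower number from compound 3 to compound 4 (0.03 log units; within the scatter)), and all four aryls on the chain now read alike in this assay. Nothing available here accounts for this insensitivity.

Still open, on these data alone, is whether the read-out stays unmoved with an amine or a carboxylic acid on the phenyl, or with a longer chain in place of the double-bonded one. As far as these compounds go, the phenyl on the shared core is the same in all four compounds, so replacing it remains untested in these data.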